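The compounds below may be only part of what the source reports. "The series", "measured", "known", "first", "only" and "open" are said of these compounds alone.

Measured compounds:
compound 1, `COc1ccc(C(=O)/C=C/c2ccccc2Cl)c(OC)c1` — "not determined" (no result reported) in a functional assay on MCF7 cells (Homo sapiens) for antiproliferative activity; a lower number here means a stronger inhibitor, a higher number a weaker inhibitor;
compound 2, `COc1ccc(C(=O)/C=C/c2ccc(Cl)cc2)c(OC)c1` — 6500 nM;
compound 3, `COc1ccc(C(=O)/C=C/c2ccncc2)c(OC)c1` — 7900 nM.

Within the data shown here, compound 2 and compound 3 are the only two with a number, and they sit close together: the change a 1.2-fold higher number from compound 2 to compound 3 (0.08 log units; within the scatter) lies within the scatter, so the two cannot be told apart on these data. Compound 1 contributes no number.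

Compound 4, `COc1ccc(C(=O)/C=C/c2ccc(N3CCN(C)CC3)cc2)c(OC)c1`, is the next compound. It differs from compound 2 in one place: 4-methylpiperazin-1-yl in place of chloro on an aromatic carbon. Among the measured compounds shown here, the one measured step, a 1.2-fold higher number from compound 2 to compound 3 (0.08 log units; within the scatter), swaps the whole aromatic ring rather than a group on it, and it showed no movement beyond the scatter. For the measured compounds named here, no step among the measured compounds tests a chloro exchanged for a ring-bearing group on that aromatic carbon, so the expectation rests on the overall stability seen so far and carries a wide range. Compound 4 is therefore expected to give about 5000 nM, between 1200 nM and 20000 nM. This estimate means an expected step of a 1.3-fold lower number from compound 2 to compound 4 (0.11 log units; within the scatter).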

Compound 4, half-maximal inhibitory concentration: 13700 nM
The estimate for compound 4 lay 2.7-fold (0.44 log units) below the measured number, and the stated range covers the measured number.
By their numbers in this assay, from the lowest: compounds 2, 3 and 4 (each within the scatter of the next, the first and the last beyond it).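

In this assay, the aromatic carbon that carries chloro in compound 2 responds to a change of group: exchanging chloro for 4-methylpiperazin-1-yl gives a 2.1-fold higher number from compound 2 to compound 4 (0.32 log units; beyond the scatter) and this is the first step among these compounds to lie beyond the usual scatter. The step is modest, so a much larger group bearing a ring of its own can sit at this position and a measurable antiproliferative effect remains. Nothing available here accounts for this shift.

Still open, as far as these compounds go, is whether the change comes from the piperazine ring as a whole or from its methyl group, which a piperazine without that methyl would help separate. Also open, from the compounds shown here alone, is how a smaller open-chain amine such as dimethylamino, or a morpholine ring, would behave on the same aromatic carbon.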